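The source may hold more compounds than are shown below. What is called first, only, known or untested is meant among the compounds shown, and "the series" means these compounds.

Measured so far:
- compound 1, `CCCC(O)C1=CC(=O)c2c(OC)ccc(OC)c2C1=O`: 0.409 ug/mL
- compound 2, `CCC(O)c1cc(OC)c2c(c1OC)C(=O)C=CC2=O`: 0.085 ug/mL

In a functional assay on L1210 cells (Mus musculus) for cytotoxicity (on this read-out lower numbers stand for an effect already at smaller amounts and higher numbers for an effect only at larger amounts of compound), compound 1 gives 0.409 ug/mL, the highest of the two numbers; compound 2 gives 0.085 ug/mL, a gap that lies beyond the scatter. Compound 3, `CCCCC(O)C1=CC(=O)c2c(OC)ccc(OC)c2C1=O`, has not yet been measured in this assay. It differs from compound 1 by methyl in place of hydrogen on a saturated chain carbon, four bonds along the chain from a double-bonded ring carbon and an oxygen on a saturated carbon. Among the compounds with values here, with no measured step of this kind to lean on, the expected change is small, within the scatter, in either direction. For compound 3 the estimate is 0.35 ug/mL, a step of a 1.2-fold lower number from compound 1 to compound 3 (0.07 log units; within the scatter), with a range from 0.15 ug/mL to 0.9 ug/mL.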

Compound 3, concentration for half-maximal effect: 0.412 ug/mL
Compound 3: middle estimate off by 1.2-fold (0.07 log units), on the low side, within the range that was stated.
By their numbers in this assay, from the lowest: compound 2; then compounds 1 and 3 (each within the scatter of the next).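

In this assay, going from propyl to butyl on this chain gives a 1.0-fold higher number from compound 1 to compound 3 (0.00 log units; within the scatter), so the two compounds stand within the scatter of each other. Within the data shown here, this is the only measured step at this position, and it shows that here one added methyl leaves no difference that the assay can separate from scatter. On these data alone, whether a longer chain or an amine at the chain end would behave the same way stays open. No measurement at hand speaks to what lies behind this result.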